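The source may report more compounds than this note shows. Statements on the series, on what has been measured and on what is new or still open speak of the compounds shown alone.

Measured compounds:
Compound 1, `CCOC(=O)c1sc(-c2ccccn2)nc1N1CCC(NCc2ccc(OCc3ccccc3)cc2)CC1` — in an ADME assay on RAW264.7 cells (Mus musculus) for cytotoxicity, read by MTT assay, with a stated time of 72 h, tested at 50 uM (a higher number here means more inhibition at the concentration tested (going by the name of the read-out), a lower number less inhibition), compound 1 gives 12.8%.
Compound 2, `CCOC(=O)c1sc(-c2ccccn2)nc1N1CCC(NCc2ccc(C(F)(F)F)cc2)CC1` — in this assay compound 2 gives 14.6%.
Compound 3, `CCOC(=O)c1sc(-c2ccncc2)nc1N1CCC(NCc2ccc(OCc3ccccc3)cc2)CC1` — in this assay compound 3 gives 8.04%.

Within the data shown here, all three numbers are small, and no two of them lie apart by more than the usual scatter of repeated measurements, so no compound can be said to give a higher or lower number than another on this evidence. The step from compound 1 to compound 2 is trifluoromethyl in place of benzyloxy on an aromatic carbon; in this assay it made a number 1.8 percentage points higher from compound 1 to compound 2 (within the scatter). The step from compound 1 to compound 3 is pyridin-4-yl in place of pyridin-2-yl on an aromatic carbon; in this assay it made a number 4.8 percentage points lower from compound 1 to compound 3 (within the scatter).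

Compound 4, `CCOC(=O)c1sc(-c2ccncc2)nc1N1CCC(NCc2ccc(C(F)(F)F)cc2)CC1`, has not yet been measured. It differs from compound 3 by trifluoromethyl in place of benzyloxy on an aromatic carbon, which is the same kind of change as that from compound 1 to compound 2, made on the core of compound 3 rather than that of compound 1. How those two cores differ is told by pyridin-4-yl in place of pyridin-2-yl on an aromatic carbon. Because the earlier step of a number 1.8 percentage points higher from compound 1 to compound 2 (within the scatter) stayed within the scatter, the same change from compound 3 to compound 4 is expected to make a step of about a number 2 percentage points higher from compound 3 to compound 4 (within the scatter) in this assay. Compound 4 is therefore estimated to give 10%, with a plausible range from 1% to 20%.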

Compound 4, a percentage reported as inhibition, at one concentration (the size of the read-out at that concentration, not a potency): 18.1%
Compound 4: middle estimate off by 8.1 percentage points, on the low side; the measured number falls inside the stated range.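

In this assay, trifluoromethyl in place of benzyloxy on the core of compound 3 gave a number 10.1 percentage points higher from compound 3 to compound 4 (beyond the scatter), yet this step cannot be told apart from the earlier one on the core of compound 1: the same change on two cores in this assay, a number 1.8 percentage points higher (within the scatter) from compound 1 to compound 2 and a number 10.1 percentage points higher (beyond the scatter) from compound 3 to compound 4, 8.3 percentage points apart, within the scatter of two such steps

Pyridin-4-yl in place of pyridin-2-yl gave a number 3.5 percentage points higher from compound 2 to compound 4 (within the scatter), and this step likewise agrees with its earlier counterpart: the same change on two cores in this assay, a number 4.8 percentage points lower (within the scatter) from compound 1 to compound 3 and a number 3.5 percentage points higher (within the scatter) from compound 2 to compound 4, 8.3 percentage points apart, within the scatter of two such steps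

So, as far as these four compounds can tell, each change carries from one core to the other without a measurable difference, but this does not show that the steps are equal, since the gap between each pair is large beside the steps themselves and only two cores are compared.

The compounds shown leave open whether the same holds for other groups in the place of benzyloxy and trifluoromethyl, such as an amine or a carboxylic acid. They also leave open how pyridin-3-yl would behave in place of the two pyridine groups shown, and whether a change elsewhere in the molecule, such as an amide in place of the ester, would carry across these cores in the same way.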